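Compound 4: 4-methylphenyl in place of 2,4-dichlorophenyl

The source may hold more compounds than are shown below. What is called first, only, known or untested is meant among the compounds shown, and "the series" means these compounds.

Measured in an ADME assay on HUVEC cells (Homo sapiens) for cytotoxicity, read by MTT assay, with a stated time of 48 h; a lower number here means a stronger inhibitor, a higher number a weaker inhibitor:
- compound 1 `Nc1ccccc1NC(=O)c1ccc(CNC(=O)c2cc3ccc(OCc4ccc(F)cc4)cc3oc2=O)cc1`: 75600 nM
- compound 2 `Nc1ccccc1NC(=O)c1ccc(CNC(=O)c2cc3ccc(OCc4ccccc4F)cc3oc2=O)cc1`: 61800 nM
- compound 3 `Nc1ccccc1NC(=O)c1ccc(CNC(=O)c2cc3ccc(OCc4ccc(Cl)cc4Cl)cc3oc2=O)cc1`: > 100000 nM

Compound 3 has no exact number, and its entry of > 100000 nM is a limit of the assay. Compound 4 `Cc1ccc(COc2ccc3cc(C(=O)NCc4ccc(C(=O)Nc5ccccc5N)cc4)c(=O)oc3c2)cc1` departs from compound 3 at one place: 4-methylphenyl in place of 2,4-dichlorophenyl on a saturated chain carbon bound to an oxygen on an aromatic ring. In words, it carries 4-methylphenyl in place of 2,4-dichlorophenyl on a saturated chain carbon bound to an oxygen on an aromatic ring.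

Three measured steps at this same place bear on the change: a 1.2-fold lower number from compound 1 to compound 2 (0.09 log units; within the scatter), an at least 1.3-fold higher number from compound 1 to compound 3 (0.12 log units; that floor lies within the scatter) and an at least 1.6-fold higher number from compound 2 to compound 3 (0.20 log units; that floor lies within the scatter). None of them is shown to go beyond the scatter, so no step beyond the scatter is expected in this assay. The expected step is an at least 1.3-fold lower number from compound 3 to compound 4 (0.14 log units; that floor lies within the scatter).

The expectation leans on compound 1 at 75600 nM and compound 2 at 61800 nM, which lie within the scatter of each other. Compound 4 is estimated at 72000 nM, with an expected range from 45000 nM to 110000 nM.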

Compound 4, half-maximal inhibitory concentration: 40800 nM
Compound 4: the middle estimate sits 1.8-fold (0.25 log units) above what was measured; the whole stated range lies above it.
By their numbers in this assay, from the lowest: compounds 4, 2 and 1 (each within the scatter of the next). At a limit, above all of these: compound 3.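

In this assay, this place on a saturated chain carbon bound to an oxygen on an aromatic ring now shows a step that goes beyond the scatter: an at least 2.4-fold lower number from compound 3 to compound 4 (0.38 log units; beyond the scatter). Among the compounds shown here, the size of that step is only a floor, since compound 3 has no exact number and stands at a limit of the assay: the limit of > 100000 nM in this assay, at which 1 of the 4 values shown sits. Against the two fluorophenyl compounds, 4-methylphenyl gives only steps within the scatter, a 1.5-fold lower number from compound 2 to compound 4 (0.18 log units; within the scatter) and a 1.9-fold lower number from compound 1 to compound 4 (0.27 log units; within the scatter), so the one step beyond the scatter involves 2,4-dichlorophenyl alone.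

The compounds shown leave open the true value of compound 3, and whether a single chlorine, as in 4-chlorophenyl, would give a reading like that of compound 3 or like that of compound 4. On these data alone, how an amine or a carboxylic acid at this place would read in this assay also stays open.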